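Lengthening the chain of compound 3: an expected gain

A few compounds are considered here, and "the series" means these few. Any claim that something is new, unique, unknown or untested is made for them only; others in the source may bear on it.

Measured in a functional assay on MCF7 cells (Homo sapiens) for antiproliferative activity, read by MTT assay, with a stated time of 72 h (on this read-out higher numbers stand for weaker inhibition and lower numbers for stronger inhibition), so far:
Compound 1 `CCCCCCCCCCCNC[C@@H]1OC[C@H](N)[C@@H]1O`: 6770 nM
Compound 2 `CCCCCCCCCNC[C@@H]1OC[C@H](N)[C@H]1O`: 60300 nM
Compound 3 `CCCCCCCNC[C@@H]1OC[C@H](N)[C@H]1O`: > 128000 nM (a limit of the assay, not a number)

Compound 3 has no exact value and stands at the limit of > 128000 nM in this assay, at which 1 of the 3 values shown sits, on this scale. Compound 4 `CCCCCCCCCCCNC[C@@H]1OC[C@H](N)[C@H]1O` would keep the core of compound 3 and carry a longer chain, with butyl in place of hydrogen on a saturated chain carbon, seven bonds along the chain from an amine nitrogen as the full change: butyl in place of hydrogen on a saturated chain carbon, seven bonds along the chain from an amine nitrogen.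

Among the measured compounds shown here, one measured step bears directly on this. It sits at the same place but runs the other way and is smaller, with hydrogen in place of ethyl giving an at least 2.1-fold higher number from compound 2 to compound 3 (0.32 log units; beyond the scatter) as its size. Going by these compounds, its true size stays open, with one end resting on a limit. Compound 1 carries the chain that compound 4 would carry but differs from it in spatial arrangement at one carbon of the core. Compound 1 reads 6770 nM in this assay and so offers only a rough guide.

A clear drop beyond the scatter is therefore expected, an estimated at least 12-fold lower number from compound 3 to compound 4 (1.10 log units; beyond the scatter) in size. For compound 4 the estimate is 10000 nM with an expected range from 3000 nM to 35000 nM on this read-out.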

Compound 4, half-maximal inhibitory concentration: 13100 nM
Estimate against measurement, compound 4: 1.3-fold (0.12 log units) below, within the range that was stated.
By their numbers in this assay, from the lowest: compounds 1 and 4 (each within the scatter of the next); then compound 2. At a limit, above all of these: compound 3.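

In this assay, butyl in place of hydrogen on a saturated chain carbon, seven bonds along the chain from an amine nitrogen, brings a clear gain (an at least 9.7-fold lower number from compound 3 to compound 4 (0.98 log units; beyond the scatter)), and ethyl in place of hydrogen, nine bonds along the chain from that nitrogen, still brings a gain (a 4.6-fold lower number from compound 2 to compound 4 (0.66 log units; beyond the scatter)), so among compounds 2, 3 and 4 the number keeps falling as the chain grows, beyond the point that compound 2 had reached. The first of these steps has no exact size, since compound 3 carries a limit of the assay and not a number: the limit of > 128000 nM in this assay, at which 1 of the 4 values shown sits. With this long chain, the drawn configuration at one saturated ring carbon makes no difference beyond the scatter (a 1.9-fold higher number from compound 1 to compound 4 (0.29 log units; within the scatter)), and this comparison isolates that one feature: the fact that compounds 1 and 4 differ only in the configuration as drawn.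

Going by these compounds, whether a chain longer than that of compound 4 would lower the number further, or would reverse the trend, remains open, as does the effect of a phenyl ring at the end of the chain. On these data alone, the other stereo elements of the shared core also remain untested by these compounds.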